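A few compounds are considered here, and "the series" means these few. Any claim that something is new, unique, unknown or untested is made for them only; others in the source may bear on it.

Measured so far in a functional assay on A549 cells (Homo sapiens) for antiproliferative activity, read by MTT assay, with a stated time of 48 h; a higher number here means a weaker inhibitor, a lower number a stronger inhibitor:
compound 1 `COc1ccc(/C=C/C(=O)Nc2nnc(-c3ccccc3)s2)cc1`: 0.76 ug/mL
compound 2 `O=C(/C=C/c1ccc(F)cc1)Nc1nnc(-c2ccc(Cl)cc2)s1`: 2.06 ug/mL

Compound 2 stands at the higher number of the two, which makes it the weaker inhibitor of the pair, and its gap to compound 1 lies beyond the scatter. These two compounds differ in more than one place, so that gap cannot be assigned to any single change. Compound 3 `COc1ccc(/C=C/C(=O)Nc2nnc(-c3ccc(Cl)cc3)s2)cc1` keeps everything in compound 2 except one group: methoxy in place of fluoro on an aromatic carbon, para to a large group (methoxy in place of fluoro on an aromatic carbon). Going by the values given here, no step between measured compounds isolates this change, so the data give no direct measure of it. Among the compounds with values here, the only guide is compound 1, which carries the same 4-methoxyphenyl and gives 0.76 ug/mL. A modest move toward lower numbers in this assay is therefore expected, of a size that may not clear the scatter. The expected change is a 1.7-fold lower number from compound 2 to compound 3 (0.23 log units; within the scatter). The estimate for compound 3 is 1.2 ug/mL, with an expected range from 0.4 ug/mL to 3.5 ug/mL.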

Compound 3, half-maximal inhibitory concentration: 1.38 ug/mL
Estimate against measurement, compound 3: 1.2-fold (0.06 log units) below, and the stated range covers the measured number.
By their numbers in this assay, from the lowest: compounds 1, 3 and 2 (each within the scatter of the next, the first and the last beyond it).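

In this assay, the replacement of fluoro by methoxy on an aromatic carbon, para to a large group, now has a direct reading with the chloro group held constant (a 1.5-fold lower number from compound 2 to compound 3 (0.17 log units; within the scatter)), and it shows that 4-fluorophenyl and 4-methoxyphenyl are not separated at this position in this setting. Going by these compounds alone, the compounds also give a first reading of chloro in place of hydrogen on an aromatic carbon with the 4-methoxyphenyl held constant (a 1.8-fold higher number from compound 1 to compound 3 (0.26 log units; within the scatter)), and this single change is likewise not separated from the scatter. No further measurement bears on why either change behaves as it does.

The compounds shown leave open whether any group at the position that carries fluoro or methoxy can move the number beyond the scatter, for example an amine, a hydroxyl or a longer chain such as butoxy. They also leave open whether a bromo group or a nitrile in the place of the chloro group would give a clearer step.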